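This account rests on a few compounds, and the source may have more. Where it says the series, first, only, none or still open, it means among the compounds named here.

Working notes on the series.

Compound 1 `O=C(CN(c1nc(Cl)nc2[nH]cnc12)C1CC1)N[C@@H](CO)C(=O)OCc1ccccc1` gives 27.9% in a functional assay on the whole organism (Tail, strain ICR) with Mus musculus as the target, in the tail flick test, with a stated time of 150 min, at a dose of 25 umol/kg by the oral route (on this read-out higher numbers stand for a stronger effect at the one dose given and lower numbers for a weaker effect), the highest of the three numbers in hand. Compound 2 `O=C(CN(c1nc(Cl)nc2[nH]cnc12)C1CC1)N[C@@H](CO)C(=O)O` gives 18.8% in this assay; the step of a number 9.1 percentage points lower from compound 1 to compound 2 (within the scatter) is within the scatter. Compound 3 `CC[C@H](C)[C@H](NC(=O)CN(c1ncnc2c1ncn2C1CCCCO1)C1CC1)C(=O)OCc1ccccc1` gives 16.4% in this assay, the value furthest from compound 1, with a gap beyond the scatter; the two differ in more than one place, so the two values are all that can be read from that pair.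

Compound 4 `CSCC[C@H](NC(=O)CN(c1nc(Cl)nc2[nH]cnc12)C1CC1)C(=O)OCc1ccccc1` is not yet measured. Relative to compound 1 the change is (methylsulfanyl)methyl in place of hydroxy on a saturated chain carbon, two bonds along the chain from an amide-type nitrogen and a carbonyl carbon. Going by the values given here, no measured step touches this position in the same way; the one step at a different position, a number 9.1 percentage points lower from compound 1 to compound 2 (within the scatter), stayed within the scatter, and compound 3, with a larger side chain and a different core, lies beyond the scatter below compound 1. On that footing compound 4 is expected to give a number close to compound 1, with an estimated step of a number 5.9 percentage points lower from compound 1 to compound 4 (within the scatter) that is within the scatter, the uncertainty reaching both ways. The estimate for compound 4 is 22%, with a range from 8% to 38%.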

Compound 4, a percentage reported as activity, at one dose (the size of the read-out at that dose, not a potency): 17.6%
The estimate for compound 4 lay 4.4 percentage points above the measured number; the measured number falls inside the stated range.
By their numbers in this assay, from the lowest: compounds 3, 4, 2 and 1 (each within the scatter of the next, the first and the last beyond it).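

Going by these compounds alone, the step of a number 10.3 percentage points lower from compound 1 to compound 4 (beyond the scatter), read in this assay, is the first single-place step to lie beyond the scatter, and it falls on a saturated chain carbon, two bonds along the chain from an amide-type nitrogen and a carbonyl carbon. Within the data shown here, the only earlier single-place step, a number 9.1 percentage points lower from compound 1 to compound 2 (within the scatter), concerned the benzyl group and stayed within the scatter, so this side-chain position is the first place where one change is seen to move the number, though only modestly. No measured information bears on the origin of this step.

Among these compounds, the single pair does not separate the loss of hydroxy from the entry of (methylsulfanyl)methyl. Also open, from the compounds shown here alone, is how a plain ethyl chain, a longer chain, an amine or a carboxylic acid at this position would read on the shared core.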